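The compounds below may be only part of what the source reports. "The series", "measured", "known", "first", "only" and "open" are said of these compounds alone.

Among the measured compounds shown here, compound 2 `COc1ccc(CNCCCNS(=O)(=O)c2cc(C(F)(F)F)cc(C(F)(F)F)c2)cc1` gives 2800 nM in a functional assay on BE(2)-C cells (Homo sapiens) for inhibition, read by MTT assay, with a stated time of 72 h (a higher number here means a weaker inhibitor of growth, a lower number a stronger inhibitor of growth), one of only two numbers measured so far, and its partner compound 1 `O=S(=O)(NCCCNCc1ccc(C(F)(F)F)cc1)c1cc(C(F)(F)F)cc(C(F)(F)F)c1` gives 2700 nM, a gap that lies within the scatter. Compound 3 `O=S(=O)(NCCCNCc1cccc(Cl)c1)c1cc(C(F)(F)F)cc(C(F)(F)F)c1` differs from compound 2 by 3-chlorophenyl in place of 4-methoxyphenyl on a saturated chain carbon bound to an amine nitrogen. For the measured compounds named here, the one measured change of a similar kind, a 1.0-fold higher number from compound 1 to compound 2 (0.02 log units; within the scatter), stayed within the scatter, so a step of no more than that size, with no clear direction, is expected: a 1.0-fold lower number from compound 2 to compound 3 (0.02 log units; within the scatter). Compound 3 is therefore estimated at 2700 nM, with a range from 1200 nM to 6500 nM.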

Compound 3, concentration for 50% growth inhibition: 6900 nM
The estimate for compound 3 lay 2.6-fold (0.41 log units) below the measured number; the measured number lies above the stated range.
By their numbers in this assay, from the lowest: compounds 1 and 2 (each within the scatter of the next); then compound 3.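

Unlike the swap of 4-(trifluoromethyl)phenyl for 4-methoxyphenyl, this change does register at this position, on a saturated chain carbon bound to an amine nitrogen. With 3-chlorophenyl the inhibitor is modestly weaker on both comparisons (a 2.5-fold higher number from compound 2 to compound 3 (0.39 log units; beyond the scatter)) and (a 2.6-fold higher number from compound 1 to compound 3 (0.41 log units; beyond the scatter)). Nothing available explains this loss. The 3-chlorophenyl group differs from the other two in both its substituent and that substituent's place on the ring, and these compounds cannot separate the two. On these data alone, how a nitrile or an unsubstituted phenyl would behave here remains open.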